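Shortening and hydroxylating the side chain of compound 3

A few compounds are considered here, and "the series" means these few. Any claim that something is new, unique, unknown or untested is made for them only; others in the source may bear on it.

Compound 3 `CCCCCCCOc1ccc(CCC(N)(CO)CCCC)cc1` stands at the edge of what was measured: in a functional assay on the whole organism (spleen, spleen) with Rattus norvegicus as the target (on this read-out lower numbers stand for an effect already at smaller amounts and higher numbers for an effect only at larger amounts of compound), compound 3 gives > 10 mg/kg, which is a limit of the assay and not a number (the limit of > 10 mg/kg in this assay, at which 1 of the 3 values shown sits). Compound 1 `C=CCC(N)(CO)CCc1ccc(OCCCCCCC)cc1` gives 1.9 mg/kg and compound 2 `CCCCCCCOc1ccc(CCC(N)(CO)C(C)C)cc1` gives 2.7 mg/kg in this assay. Compound 4 `CCCCCCCOc1ccc(CC[C@@](N)(CO)CCO)cc1` differs from compound 3 by a group of 7 heavy atoms (4 carbon, 1 nitrogen, 2 oxygen; no ring) in place of a group of 8 heavy atoms (6 carbon, 1 nitrogen, 1 oxygen; no ring), on a saturated chain carbon, two bonds along the chain from an aromatic carbon. Going by the values given here, the steps that bear on this change are an at least 5.2-fold higher number from compound 1 to compound 3 (0.72 log units; beyond the scatter) and an at least 3.7-fold higher number from compound 2 to compound 3 (0.56 log units; beyond the scatter), both going from a smaller group to butyl and both raising the number. Since the entering group is again smaller than the leaving one, a step back down, an at least 2.5-fold lower number from compound 3 to compound 4 (0.39 log units; beyond the scatter), is expected. Compound 4 is therefore estimated at 4 mg/kg, between 1.5 mg/kg and 10 mg/kg.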

Compound 4, dose for 50% inhibition: 0.017 mg/kg
Compound 4: the middle estimate sits 240-fold (2.37 log units) above what was measured; the whole stated range lies above it.
By their numbers in this assay, from the lowest: compound 4; then compounds 1 and 2 (each within the scatter of the next). At a limit, above all of these: compound 3.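

In this assay, going by these compounds alone, this place, on a saturated chain carbon, two bonds along the chain from an aromatic carbon, moves the number much further than the earlier steps showed, with a 160-fold lower number from compound 2 to compound 4 (2.20 log units; beyond the scatter) and a 110-fold lower number from compound 1 to compound 4 (2.05 log units; beyond the scatter). Compound 3 gives only a limit of the assay: the limit of > 10 mg/kg in this assay, at which 1 of the 4 values shown sits. Measured against that limit, the change gives an at least 580-fold lower number from compound 3 to compound 4 (2.76 log units; beyond the scatter).

The compounds shown leave open whether the gain follows the terminal hydroxyl or the defined stereocentre, which only compound 4 carries. They also leave open whether a longer hydroxyalkyl chain, a methyl ether or an amine at the chain end would keep it.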